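The compounds below may be only part of what the source reports. "The series", "measured", "known", "first", "only" and "open" are said of these compounds alone.

Working notes on the series. Among the compounds with values here, in a functional assay on MGC-803 cells (Homo sapiens) for antiproliferative activity, read by CCK-8 assay, with a stated time of 72 h, tested at 2 uM (on this read-out higher numbers stand for a stronger effect at the one concentration tested and lower numbers for a weaker effect), compound 1 `Nc1ccccc1NC(=O)c1ccc(CSC(=S)N2CCN(c3ccccc3)CC2)cc1` gives 42.3% and compound 2 `Nc1ccccc1NC(=O)c1ccc(CSC(=S)N2CCN(c3ccc(F)cc3)CC2)cc1` gives 18.8%; the only change between them is a number 23.5 percentage points lower from compound 1 to compound 2 (beyond the scatter). Compound 3 `CC1CCCCN1C(=S)SCc1ccc(C(=O)Nc2ccccc2N)cc1` gives 64.4%, the highest of the three numbers, with compound 1 nearest and compound 2 furthest, both beyond the scatter. Compound 4 `CN1CCN(C(=S)SCc2ccc(C(=O)Nc3ccccc3N)cc2)CC1` carries 4-methylpiperazin-1-yl in place of 2-methylpiperidin-1-yl on a thiocarbonyl carbon. Within the data shown here, the one measured step concerns a fluoro on an aromatic carbon and does not bear on a swap of the ring at the thiocarbonyl carbon, so no measured step guides the size here; the spread between compound 3 and compound 1 shows that this part of the molecule moves this assay beyond the scatter. A downward step a number 16.4 percentage points lower from compound 3 to compound 4 (beyond the scatter) is therefore expected, with wide uncertainty. Compound 4 is estimated at 48%, between 25% and 70%.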

Compound 4, a percentage reported as inhibition, at one concentration (the size of the read-out at that concentration, not a potency): 29.6%
Compound 4: middle estimate off by 18.4 percentage points, on the high side; measured number inside the range.
By their numbers in this assay, from the lowest: compound 2; then compound 4; then compound 1; then compound 3.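

On a thiocarbonyl carbon, the ring group matters more than the earlier spread suggested: 4-methylpiperazin-1-yl in place of 2-methylpiperidin-1-yl gives a number 34.8 percentage points lower from compound 3 to compound 4 (beyond the scatter). On the amine nitrogen in a ring, methyl does not move the number in one direction: it gives a number 12.7 percentage points lower from compound 1 to compound 4 (beyond the scatter) against phenyl, but a number 10.8 percentage points higher from compound 2 to compound 4 (beyond the scatter) against 4-fluorophenyl. Nothing on hand explains these steps. The compounds shown leave open what the methyl on 2-methylpiperidin-1-yl contributes, since the unsubstituted piperidin-1-yl does not appear among them. Going by these compounds, how an acetyl or a 2-hydroxyethyl group on the amine nitrogen in a ring would compare with methyl also remains open.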